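Trimming One Methyl from the Dimethylphenyl Arm

This account rests on a few compounds, and the source may have more. Where it says the series, first, only, none or still open, it means among the compounds named here.

Measured so far:
compound 1, `CCCc1nc(-c2ccccc2)c(CNCCCN2CCN(c3ccc(C(F)(F)F)cc3)CC2)o1`: 51.6%
compound 2, `CCCc1nc(-c2ccccc2)c(CNCCN2CCN(c3cccc(C)c3C)CC2)o1`: 66.7%

In an assay on HEK293 cells for inhibition of Voltage-dependent T-type calcium channel subunit alpha-1G (Homo sapiens), read by fluorescence, tested at 10 uM (a lower number here means less inhibition, a higher number more inhibition at the concentration tested (going by the name of the read-out)), compound 2 gives 66.7%, the higher of the two numbers, while compound 1 gives 51.6%, a gap beyond the usual scatter. Compound 3, `CCCc1nc(-c2ccccc2)c(CNCCN2CCN(c3ccccc3C)CC2)o1`, keeps the core of compound 2 and differs in one place: hydrogen in place of methyl on an aromatic carbon, so 2,3-dimethylphenyl becomes 2-methylphenyl. Among the measured compounds shown here, no pair of measured compounds isolates this change, so its size is not known from the data. Since only a methyl is removed, the step of a number 8.7 percentage points lower from compound 2 to compound 3 (within the scatter) is expected to be small, pointing downward, and within scatter. Compound 3 is expected to give 58%, within 40% to 75%.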

Compound 3, a percentage reported as inhibition, at one concentration (the size of the read-out at that concentration, not a potency): 51.3%
The estimate for compound 3 lay 6.7 percentage points above the measured number, and the stated range covers the measured number.
By their numbers in this assay, from the lowest: compounds 3 and 1 (each within the scatter of the next); then compound 2.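

Among the compounds shown here, removing one methyl, so that 2,3-dimethylphenyl becomes 2-methylphenyl, gives the first measured step at this position: in this assay, the change is a number 15.4 percentage points lower from compound 2 to compound 3 (beyond the scatter). A single carbon at this aromatic position is therefore enough to change the inhibition seen at the tested concentration. Nothing available explains why the number falls. Going by these compounds, it remains open what the methyl that stays contributes, and whether an ethyl, a chlorine or a methoxy in place of the removed methyl would match compound 2.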